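The source may hold more compounds than are shown below. What is called first, only, known or untested is meant among the compounds shown, and "the series" means these compounds.

Measured in a functional assay on the whole organism for inhibition, with Rattus norvegicus as the target, read by paw edema, in the formalin test, with a stated time of 8 h, at a dose of 100 mg/kg by the intraperitoneal route; a higher number here means more inhibition at the dose given (going by the name of the read-out), a lower number less inhibition:
compound 1 `O=c1cc(CNc2nc(-c3cc4cc(Br)cc(Br)c4oc3=O)cs2)c2cc(Cl)ccc2[nH]1` — 21.9%
compound 2 `Cc1cccc2c(CNc3nc(-c4cc5cc(Br)ccc5oc4=O)cs3)cc(=O)[nH]c12` — 18.5%
compound 3 `O=c1cc(CNc2nc(-c3cc4cc(Br)cc(Br)c4oc3=O)cs2)c2ccc(Cl)cc2[nH]1` — 41.5%

Compound 2 lies within the scatter of compound 1 in this assay; compound 3 gives a number beyond the scatter above compound 2. No two of these compounds differ in only one place, so no single measured step is available. Compound 4 `Cc1cccc2c(CNc3nc(-c4cc5cc(Br)cc(Br)c5oc4=O)cs3)cc(=O)[nH]c12` differs from compound 2 by bromo in place of hydrogen on an aromatic carbon. Compound 1 and compound 3 also carry a bromo group at that position, and their numbers fall on either side of the scatter around compound 2, so the change gives no clear direction on its own. The step from compound 2 to compound 4 is expected to be small, upward if anything, and may stay within the scatter: a number 7.5 percentage points higher from compound 2 to compound 4 (within the scatter). Compound 4 is estimated at 26%, with a range from 12% to 42%.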

Compound 4, a percentage reported as inhibition, in the whole organism at one dose (the size of the read-out at that dose, not a potency): 33.7%
Beside the measured number, compound 4's estimate is 7.7 percentage points below it; measured number inside the range.
By their numbers in this assay, from the lowest: compounds 2 and 1 (each within the scatter of the next); then compounds 4 and 3 (each within the scatter of the next).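

In this assay, among these compounds, bromo in place of hydrogen on an aromatic carbon, ortho to a fused ring, gives a number 15.2 percentage points higher from compound 2 to compound 4 (beyond the scatter), the first single-place step. The number at this position therefore responds to the added bromo group, by more than the scatter, which compounds differing in several places could not show. Nothing measured here accounts for the step.

Going by these compounds, whether fluoro or methoxy at this position would give a similar step remains open. So does whether bromo would give the same step on a core other than that of compound 2.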